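From benzyloxy to (pyrrolidin-1-yl)methyl on the carbonyl

The source may hold more compounds than are shown below. What is called first, only, known or untested is meant among the compounds shown, and "the series" means these compounds.

In a functional assay on the whole organism for inhibition, with Mus musculus as the target (on this read-out higher numbers stand for an effect only at larger amounts of compound and lower numbers for an effect already at smaller amounts), compound 1 `CCCCNC(=O)Nc1cccc2c1CN(C)CC2c1ccc(Cl)cc1` gives 44 mg/kg. Compound 2 `CN1Cc2c(NC(=O)OCc3ccccc3)cccc2C(c2ccccc2)C1` gives about 15 mg/kg, the lower of the two numbers, and the gap between them lies beyond the usual scatter. Compound 3 `CN1Cc2c(NC(=O)CN3CCCC3)cccc2C(c2ccccc2)C1` carries (pyrrolidin-1-yl)methyl in place of benzyloxy on a carbonyl carbon. Within the data shown here, no measured pair shows this kind of change, so only a small rise in the number, not beyond the scatter, is expected in this assay. The expected step is a 1.5-fold higher number from compound 2 to compound 3 (0.17 log units; within the scatter). The estimated value for compound 3 is 22 mg/kg, with an expected range of 7 mg/kg to 65 mg/kg.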

Compound 3, dose for half-maximal effect: 39 mg/kg
For compound 3 the middle estimate is 1.8-fold (0.25 log units) below the measured one; the range from low to high includes it.
By their numbers in this assay, from the lowest: compound 2; then compounds 3 and 1 (each within the scatter of the next).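

On the carbonyl carbon, this assay now gives a single change that can be read: (pyrrolidin-1-yl)methyl in place of benzyloxy brings a 2.6-fold higher number from compound 2 to compound 3 (0.41 log units; beyond the scatter) and so this place on the shared core is sensitive to the group it carries, with benzyloxy giving the lower number of this pair. The data at hand offer no explanation for this step. The compounds shown leave open whether phenoxy or a longer chain ending in pyrrolidine would give a number closer to that of compound 2 or of compound 3.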